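This account rests on a few compounds, and the source may have more. Where it says the series, first, only, none or still open, it means among the compounds named here.

Measured so far:
compound 1, `CC(C)=CCc1cc(C(=O)Nc2cc3ccc(OCCCN4CCCCC4)c(C)c3oc2=O)ccc1O`: > 50000 nM
compound 2, `CC(C)=CCc1cc(C(=O)Nc2cc3ccc(OCCCN4CCCC4)c(C)c3oc2=O)ccc1O`: 990 nM

In a functional assay on MCF7 cells (Homo sapiens) for antiproliferative activity (on this read-out higher numbers stand for weaker inhibition and lower numbers for stronger inhibition), compound 1 gives only a limit, > 50000 nM, so its own number is not fixed and it stands at the limit of > 50000 nM in this assay, at which 1 of the 2 values shown sits. Compound 2 gives 990 nM in this assay. For the measured compounds named here, the single measured step, an at least 50-fold lower number from compound 1 to compound 2 (1.70 log units; beyond the scatter), is the only guide for the change that leads to compound 3, `CC(C)=CCc1cc(C(=O)Nc2cc3ccc(OCCCNCC(=O)O)c(C)c3oc2=O)ccc1O`: (carboxymethyl)amino in place of piperidin-1-yl on a saturated chain carbon, three bonds along the chain from an oxygen on an aromatic ring. Both the step to compound 2 and the step to compound 3 remove piperidin-1-yl from the same place, but what enters differs: pyrrolidin-1-yl in the one case, (carboxymethyl)amino in the other. The measured step lowered the number well beyond the scatter; whether a group with no ring does the same cannot be read from two values. The expectation is therefore a number below the limit of compound 1 yet above compound 2, with wide uncertainty and a real chance that only a limit is returned again. Compound 3 is thus estimated at 10000 nM, between 1500 nM and 50000 nM, the expected step being an at least 5.0-fold lower number from compound 1 to compound 3 (0.69 log units; beyond the scatter).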

Compound 3, half-maximal inhibitory concentration: 18100 nM
Compound 3: the middle estimate sits 1.8-fold (0.26 log units) below what was measured, and the stated range covers the measured number.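

In this assay, the open-chain (carboxymethyl)amino group gives a measured number at this place, on a saturated chain carbon, three bonds along the chain from an oxygen on an aromatic ring, with an at least 2.7-fold lower number from compound 1 to compound 3 (0.44 log units; beyond the scatter), so a move away from piperidin-1-yl need not bring in a second ring for the number to fall. Set against pyrrolidin-1-yl, the same group gives an 18-fold higher number from compound 2 to compound 3 (1.26 log units; beyond the scatter), which places pyrrolidin-1-yl ahead of (carboxymethyl)amino and shows that the two replacements of piperidin-1-yl are far from equal at this place. Compound 1 stands at a limit and not at a number, so the size of the first of these steps is only a bound: the limit of > 50000 nM in this assay, at which 1 of the 3 values shown sits.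

The three compounds do not separate the effect of ring size from that of the carboxylic acid or the open-chain secondary amine; azepan-1-yl, dimethylamino and a carboxylic acid without the amine nitrogen at the same place would pull these apart. Also open, from the compounds shown here alone, is whether pyrrolidin-1-yl keeps its number on a longer chain than the 3-(pyrrolidin-1-yl)propyl group of compound 2.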